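Swapping the Amide Ring on a Thyroid Receptor Beta Series

The source may report more compounds than this note shows. Statements on the series, on what has been measured and on what is new or still open speak of the compounds shown alone.

Of the compounds shown here, three sharing one core have been tested in an assay on isolated protein for inhibition of thyroid hormone receptor beta (Homo sapiens), read by fluorescence, with a stated time of 30 min; on this read-out higher numbers stand for weaker inhibition and lower numbers for stronger inhibition. Compound 1 `CCCN(CC1CCOC1)C(=O)c1cc(CC)c2oc(NCc3cccc(Cl)c3)nc2c1` gives 104 nM. Compound 2 `COc1cc(C(=O)N2CCC(C)(C)C2)cc2nc(NCc3cccc(Cl)c3)oc12` gives 40 nM, the lowest of the three numbers; compound 1 stands nearest to it, at a gap beyond the scatter, and compound 3 furthest. Compound 3 `COc1cc(C(=O)N2CCC(O)C(C)C2)cc2nc(NCc3cncc(Cl)c3)oc12` gives 7200 nM. Compound 4 `CCC1CC(O)C(C)CN1C(=O)c1cc(OC)c2oc(NCc3cccc(Cl)c3)nc2c1` has not yet been measured; it differs from compound 2 in one place: 2-ethyl-4-hydroxy-5-methylpiperidin-1-yl in place of 3,3-dimethylpyrrolidin-1-yl on a carbonyl carbon. For the measured compounds named here, no two measured compounds differ in a single place, so no step size can be read directly from them. A modest weakening is expected, and the step from compound 2 to compound 4 is estimated at a 2.5-fold higher number from compound 2 to compound 4 (0.40 log units; beyond the scatter). Compound 4 is therefore expected to give about 100 nM, within a range of 25 nM to 500 nM.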

Compound 4, half-maximal inhibitory concentration: 13 nM
The estimate for compound 4 lay 7.7-fold (0.89 log units) above the measured number; measured number outside the range, below it.
By their numbers in this assay, from the lowest: compound 4; then compound 2; then compound 1; then compound 3.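

On the carbonyl carbon, 2-ethyl-4-hydroxy-5-methylpiperidin-1-yl in place of 3,3-dimethylpyrrolidin-1-yl gives a 3.1-fold lower number from compound 2 to compound 4 (0.49 log units; beyond the scatter), a modest gain in inhibition. This position therefore accepts a six-membered ring with a hydrogen-bond donor and acceptor without any loss of inhibition. Nothing available explains why this swap strengthens inhibition.

For the compounds shown here, the single step cannot separate the contributions of ring size and the ethyl, hydroxy and methyl groups. On these data alone, it also remains open whether an amine or a carboxylic acid on this ring would preserve the inhibition.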